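The compounds below may be only part of what the source reports. "The series", "measured", "known", "first", "only" and "open" are said of these compounds alone.

For the measured compounds named here, compound 1 `C[C@@H](O)[C@H](NC(=O)CN(c1ncnc2c1ncn2C1CCCCO1)C1CC1)C(=O)OCc1ccccc1` stands lowest of the two numbers known in a functional assay on the whole organism (Tail, strain ICR) with Mus musculus as the target, in the tail flick test, with a stated time of 150 min, at a dose of 25 umol/kg by the oral route (on this read-out higher numbers stand for a stronger effect at the one dose given and lower numbers for a weaker effect), where compound 1 gives 6.53%. Its nearest neighbour, compound 2 `NC(=O)CC[C@H](NC(=O)CN(c1nc(Cl)nc2[nH]cnc12)C1CC1)C(=O)OCc1ccccc1`, gives 31.1% in this assay, a gap beyond the usual scatter; the two differ in more than one place, so only their two values can be set side by side. Compound 3 `CC(C)[C@H](NC(=O)CN(c1ncnc2c1ncn2C1CCCCO1)C1CC1)C(=O)OCc1ccccc1` differs from compound 1 by isopropyl in place of 1-hydroxyethyl on a saturated chain carbon bound to an amide-type nitrogen and a carbonyl carbon. Going by the values given here, no single-place step has been measured, so the step expected here is a number 3.5 percentage points higher from compound 1 to compound 3 (within the scatter), a change not beyond the scatter. Compound 3 is therefore estimated at 10% in this assay, within 0% to 28%.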

Compound 3, a percentage reported as activity, at one dose (the size of the read-out at that dose, not a potency): 21.1%
Compound 3: the middle estimate sits 11.1 percentage points below what was measured; measured number inside the range.
By their numbers in this assay, from the lowest: compound 1; then compounds 3 and 2 (each within the scatter of the next).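

On a saturated chain carbon bound to an amide-type nitrogen and a carbonyl carbon, isopropyl in place of 1-hydroxyethyl gives in this assay a modest change: a number 14.6 percentage points higher from compound 1 to compound 3 (beyond the scatter). This is the only single-place step shown, and it indicates that this position responds to the change although both groups count 3 heavy atoms. No evidence available here bears on what lies behind the step.

From the compounds shown here alone, it remains open how an amine, a carboxylic acid or a longer chain at this place would read in this assay and whether the same change would give a similar step on the core of compound 2.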